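The source may report more compounds than this note shows. Statements on the series, on what has been measured and on what is new or still open speak of the compounds shown alone.

Compound 3 `CCOc1ccccc1N1CCN(Cc2nc3ccccc3[nH]2)CC1` gives the lowest of the three numbers recorded in an assay on HEK293 cells with D(4) dopamine receptor (Homo sapiens) as the target, read by FLIPR; a lower number here means a smaller maximal response, a higher number a larger maximal response. Compound 1 `N#Cc1ccccc1N1CCN(Cc2nc3ccccc3[nH]2)CC1` gives 46%, and compound 2 `N#Cc1cccnc1N1CCN(Cc2nc3ccccc3[nH]2)CC1` gives 50%; compound 3 gives 31%. Its nearest neighbour is compound 1, a number 15 percentage points lower from compound 1 to compound 3 (beyond the scatter), and its furthest is compound 2. Going by the values given here, the only other measured step is a number 4 percentage points higher from compound 1 to compound 2 (within the scatter).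

Compound 4 `CSc1ccccc1N1CCN(Cc2nc3ccccc3[nH]2)CC1` differs from compound 3 in one place: methylsulfanyl in place of ethoxy on an aromatic carbon. Among the compounds with values here, neither measured step concerns a methylsulfanyl group, so no step in the table bears directly on this change. The step from compound 1 to compound 3 shows that exchanging one small group on that aromatic carbon for another moved this assay by a modest amount; the step from compound 1 to compound 2 shows a change elsewhere left it within the scatter. On that basis the expected step from compound 3 to compound 4 is a number 4 percentage points higher from compound 3 to compound 4 (within the scatter), small and of uncertain direction. Compound 4 is therefore estimated to reach 35% in this assay, with a range from 20% to 52%.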

Compound 4, largest response reached (reported as efficacy), in percent of the reference or control that the assay uses: 42%
Beside the measured number, compound 4's estimate is 7 percentage points below it; low and high end bracket the measured number.
By their numbers in this assay, from the lowest: compound 3; then compounds 4, 1 and 2 (each within the scatter of the next).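

In this assay, the aromatic carbon ortho to a large group does not respond to ethoxy and methylsulfanyl alike: there is a number 11 percentage points higher from compound 3 to compound 4 (beyond the scatter) with methylsulfanyl in place of ethoxy, so the lower number of compound 3 does not extend to this other small group. Set against the nitrile compounds, there is a number 4 percentage points lower from compound 1 to compound 4 (within the scatter) and a number 8 percentage points lower from compound 2 to compound 4 (within the scatter) for this same compound, which places compound 4 with them and leaves compound 3 alone apart. Nothing available explains why the two groups differ in this way.

From the compounds shown here alone, it remains open whether the lower number follows the oxygen of ethoxy or the length of its chain. A methoxy group and an ethylsulfanyl group on this same carbon would separate those two readings.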